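Swapping the Amide Substituent on a Pyridine Cinnamoyl Core

This account rests on a few compounds, and the source may have more. Where it says the series, first, only, none or still open, it means among the compounds named here.

Measured compounds:
- compound 1, `O=C(O)[C@@H]1CCCN1C(=O)/C=C/c1ccncc1-c1ccc2ccccc2c1`: "not determined" (no result reported)
- compound 2, `O=C(O)/C=C/c1ccncc1-c1ccc2cc[nH]c2c1`: > 30000 nM

Both compounds were tested in a functional assay on HCT-116 cells (Homo sapiens) for inhibition, read by MTT assay, with a stated time of 72 h; on this read-out higher numbers stand for weaker inhibition of growth and lower numbers for stronger inhibition of growth. For compound 1 no number was reported in this assay, so it has no single value to stand on; it is known only by its structure. For compound 2 the result is a limit of the assay rather than a number, > 30000 nM, meaning its growth inhibition was too weak to be pinned down. This is the situation described by the limit of > 30000 nM in this assay, at which 1 of the 2 values shown sits, where one of the two values recorded is such a limit.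

The unmeasured compound 3, `O=C(/C=C/c1ccncc1-c1ccc2ccccc2c1)NC1CC1`, keeps the core of compound 1 and alters only the group on the carbonyl carbon: cyclopropylamino in place of 2-carboxypyrrolidin-1-yl on a carbonyl carbon. For the measured compounds named here, no step between measured compounds is available to guide the size of this change, and compound 1 itself has no value, so the direction in this assay cannot be anchored; the only recorded value is the limit seen for compound 2. On that footing compound 3 is expected to show weak growth inhibition, with an estimate of 15000 nM and a range from 2000 nM to 60000 nM.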

Compound 3, concentration for 50% growth inhibition: 6180 nM
The estimate for compound 3 lay 2.4-fold (0.39 log units) above the measured number, within the range that was stated.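

For the compounds shown here, compound 1 has no number in this assay, so no step from it to compound 3 can be read. The compounds shown leave open how much swapping 2-carboxypyrrolidin-1-yl for cyclopropylamino on the carbonyl carbon changes growth inhibition, and in which direction. Nothing recorded here accounts for the value of compound 3.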